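The source may report more compounds than this note shows. Statements on the series, on what has been measured and on what is new or still open speak of the compounds shown alone.

Measured in a functional assay on the whole organism (strain Charles Foster albino) for inhibition, with Rattus norvegicus as the target, read by paw edema, with stated times of 30 min and 3 h, at a dose of 50 mg/kg by the oral route; on this read-out higher numbers stand for more inhibition at the one dose given (going by the name of the read-out) and lower numbers for less inhibition:

Compound 1, `COc1cc(-c2nc(-c3cnccn3)no2)ccc1O`, gives 26%.
Compound 2, `COc1ccc(OC)c(-c2nc(-c3cnccn3)no2)c1`, gives 11%.
Compound 3, `COc1ccc(OC)c(-c2nc(-c3ccncc3)no2)c1`, gives 35%.

Compound 2 and compound 3 share a core and differ in one place: pyridin-4-yl in place of pyrazin-2-yl on an aromatic carbon. That single exchange brought a step of a number 24 percentage points higher from compound 2 to compound 3 (beyond the scatter), a change that stands out from the ordinary scatter of the read-out. Compound 1 has a different core from compound 2, and the difference between the two cores is not broken down here. Compound 4, `COc1cc(-c2nc(-c3ccncc3)no2)ccc1O`, has not yet been tested. It is related to compound 1 the way compound 3 is related to compound 2: pyridin-4-yl in place of pyrazin-2-yl on an aromatic carbon. The surroundings are described slightly differently, as a ring atom that bears a group of 9 heavy atoms rather than one that bears a large group, so this is the same kind of change rather than the same change. Carrying the observed step over, compound 4 is expected to improve on compound 1 by about a number 19 percentage points higher from compound 1 to compound 4 (beyond the scatter), because compound 3 showed a number 24 percentage points higher from compound 2 to compound 3 (beyond the scatter). The estimate for compound 4 is therefore 45%, expected to fall between 28% and 62%.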

Compound 4, a percentage reported as inhibition, in the whole organism at one dose (the size of the read-out at that dose, not a potency): 14%
Beside the measured number, compound 4's estimate is 31 percentage points above it; the whole stated range lies above it.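

In this assay, putting pyridin-4-yl in place of pyrazin-2-yl gave a number 12 percentage points lower from compound 1 to compound 4 (beyond the scatter), so the exchange did not repeat what it had done on the other core. Set side by side, the two results run in opposite directions, and the gap between them is larger than scatter alone would account for: the same change on two cores in this assay, a number 24 percentage points higher (beyond the scatter) from compound 2 to compound 3 and a number 12 percentage points lower (beyond the scatter) from compound 1 to compound 4, 36 percentage points apart, beyond the scatter of two such steps. This shows that in these two pairs the effect of the exchange depends on the core that carries it, so a step seen on one core cannot simply be added to another, but it does not show which feature of the cores is responsible, and two pairs cannot settle that.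

The compounds shown carry only pyrazin-2-yl or pyridin-4-yl at this place, so it remains open how a different group there, such as an amine or a carboxylic acid, would behave on either core. Going by these compounds, it also remains open which of the two opposite steps, if either, a third core would follow.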